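Moving the phenyl substituent: from nitro to chloro

The source may report more compounds than this note shows. Statements on the series, on what has been measured and on what is new or still open speak of the compounds shown alone.

Compound 1 `CC(C)(CCCCOc1cc(-c2ccc(C(F)(F)F)cc2)c2ccccc2n1)C(=O)O` — 300 nM
Compound 2 `CC(C)(CCCCOc1cc(-c2ccc([N+](=O)[O-])cc2)c2ccccc2n1)C(=O)O` — 150 nM
Compound 3 `CC(C)(CCCCOc1cc(-c2cccc(Cl)c2)c2ccccc2n1)C(=O)O` — not yet measured

Going by the values given here, in an assay on membranes from spleen (Cavia porcellus) for binding affinity to leukotriene B4 receptor 1 (Homo sapiens) (on this read-out higher numbers stand for weaker inhibition and lower numbers for stronger inhibition), compound 2 gives the lowest of the two numbers so far, but the step of a 2.0-fold lower number from compound 1 to compound 2 (0.30 log units; within the scatter) lies within the scatter, so the two compounds cannot be told apart. Compound 3 carries 3-chlorophenyl in place of 4-nitrophenyl on an aromatic carbon. Among the compounds with values here, the only measured step touches the same ring: trading trifluoromethyl for nitro, with the small step of a 2.0-fold lower number from compound 1 to compound 2 (0.30 log units; within the scatter). Within the data shown here, no measured pair speaks to a chloro group or to the 3-position of that ring, so the step to compound 3 is less certain. Among the measured compounds shown here, the single step available suggests the phenyl substituent shifts the number only modestly, so a step of a 2.7-fold higher number from compound 2 to compound 3 (0.43 log units; beyond the scatter) is expected, in either direction or none beyond the scatter. For compound 3 the estimate in this assay is 400 nM, with a range from 120 nM to 1500 nM.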

Compound 3, half-maximal inhibitory concentration: 1100 nM
Estimate against measurement, compound 3: 2.8-fold (0.44 log units) below; low and high end bracket the measured number.
By their numbers in this assay, from the lowest: compounds 2 and 1 (each within the scatter of the next); then compound 3.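

In this assay the aryl group on this carbon of the shared core clearly affects the number, since 3-chlorophenyl gives a step beyond the scatter against both 4-nitrophenyl (a 7.3-fold higher number from compound 2 to compound 3 (0.87 log units; beyond the scatter)) and 4-(trifluoromethyl)phenyl (a 3.7-fold higher number from compound 1 to compound 3 (0.56 log units; beyond the scatter)). Going by these compounds alone, the one earlier step, between the two other aryl groups, stayed within the scatter, so this is the first sign that the position can separate these groups, with 3-chlorophenyl the least favoured of the three. No measurement at hand gives a reason for this rise.

Whether the chloro group itself or its place on the phenyl ring accounts for the step stays open, as 3-chlorophenyl differs from the other two aryl groups in both respects. How an amine or a methoxy group on that ring would fare is also unknown.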